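A few compounds are considered here, and "the series" means these few. Any claim that something is new, unique, unknown or untested is made for them only; others in the source may bear on it.

- Compound 1 `Cn1ccnc1/C=C/C(=O)/C=C/c1coc2ccccc2c1=O`: 4500 nM
- Compound 2 `CCn1ccnc1/C=C/C(=O)/C=C/c1coc2ccccc2c1=O`: 3000 nM
- Compound 3 `CCCn1ccnc1/C=C/C(=O)/C=C/c1coc2ccccc2c1=O`: not yet measured

These values come from a functional assay on DU-145 cells (Homo sapiens) for inhibition, read by WST assay, with a stated time of 3 days; a lower number here means a stronger inhibitor, a higher number a weaker inhibitor. Among the measured compounds shown here, compound 2 has the lower of the only two numbers available, but the gap to compound 1 lies within the usual scatter, so the two cannot be ranked. Compound 3 changes ethyl to propyl on the shared core: methyl in place of hydrogen on a saturated chain carbon, two bonds along the chain from an aromatic nitrogen. This places methyl in place of hydrogen on a saturated chain carbon, two bonds along the chain from an aromatic nitrogen. For the measured compounds named here, one measured step bears on this change, a similar methyl-for-hydrogen swap on the carbon bound to the aromatic nitrogen: a 1.5-fold lower number from compound 1 to compound 2 (0.18 log units; within the scatter). That single step stays within the scatter, so no step beyond the scatter is expected in this assay. The expected step is a 1.1-fold lower number from compound 2 to compound 3 (0.03 log units; within the scatter). Compound 3 is estimated at 2800 nM, with an expected range of 1200 nM to 6500 nM.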

Compound 3, half-maximal inhibitory concentration: 4600 nM
Beside the measured number, compound 3's estimate is 1.6-fold (0.22 log units) below it; the measured number falls inside the stated range.
By their numbers in this assay, from the lowest: compounds 2, 1 and 3 (each within the scatter of the next).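

In this assay, methyl in place of hydrogen on a saturated chain carbon, two bonds along the chain from an aromatic nitrogen, gives a 1.5-fold higher number from compound 2 to compound 3 (0.19 log units; within the scatter) and so, like the earlier swap, cannot be told from repeat-measurement noise. Read as one move, the whole change along the chain gives a 1.0-fold higher number from compound 1 to compound 3 (0.01 log units; within the scatter) and shows that the methyl, ethyl and propyl compounds cannot be ranked, so the lower number of compound 2 does not start a trend. No measurement shown here offers an explanation for this result.

The compounds shown leave open whether a longer chain, such as butyl, would move the number beyond the scatter. They also leave open what a chain ending in an amine or a carboxylic acid would do at this place.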